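The source may hold more compounds than are shown below. What is called first, only, known or untested is meant among the compounds shown, and "the series" means these compounds.

Measured so far:
- compound 1 `C/C(=C\CC/C(C)=C/CC[C@@H]1[C@@]2(C)CCC(=O)C(C)(C)[C@H]2CC[C@@]1(C)O)CC/C=C(\C)C(=O)OCc1cn(-c2ccc(Br)cc2)nn1`: > 150000 nM
- compound 2 `C/C(=C\CC/C(C)=C/CC[C@@H]1[C@@]2(C)CCC(=O)C(C)(C)[C@H]2CC[C@@]1(C)O)CC/C=C(\C)C(=O)OCc1cn(-c2ccc(F)cc2)nn1`: > 150000 nM
- compound 3 `C/C(=C\CC/C(C)=C/CC[C@@H]1[C@@]2(C)CCC(=O)C(C)(C)[C@H]2CC[C@@]1(C)O)CC/C=C(\C)C(=O)OCc1cn(-c2ccc(C)cc2)nn1`: > 150000 nM

These three compounds share one core and differ only in the group carried on the aromatic nitrogen of the five-membered ring. In an ADME assay on L132 cells (Homo sapiens) for cytotoxicity, read by MTT assay, with a stated time of 48 h (a lower number here means a stronger inhibitor, a higher number a weaker inhibitor), compound 1 gives > 150000 nM, which is a limit of the assay and not a number. Compound 2 likewise gives > 150000 nM, again a limit. Compound 3 gives > 150000 nM, also a limit. Compound 3 therefore stands at the same point as the other two, namely (the limit of > 150000 nM in this assay, at which 3 of the 3 values shown sit). The steps among them, a step that the two limits leave unreadable from compound 1 to compound 2, a step that the two limits leave unreadable from compound 1 to compound 3 and a step that the two limits leave unreadable from compound 2 to compound 3, tell nothing about size. Every value is a limit.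

Compound 4 `COc1ccccc1-n1cc(COC(=O)/C(C)=C/CC/C(C)=C/CC/C(C)=C/CC[C@@H]2[C@@]3(C)CCC(=O)C(C)(C)[C@H]3CC[C@@]2(C)O)nn1` has not yet been measured. Compared with compound 3 the change is 2-methoxyphenyl in place of 4-methylphenyl on an aromatic nitrogen. For the measured compounds named here, since none of the measured steps is readable, the expectation rests only on the shared limit: compound 4 is expected to sit at the limit as well, so that a step that the limit leaves unreadable from compound 3 to compound 4 is expected to be none beyond the scatter. The estimate for compound 4 is 200000 nM, with a range from 100000 nM to 600000 nM.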

Compound 4, half-maximal inhibitory concentration: > 150000 nM
Compound 4: only a limit was reported; the forecaster's own chance of this, stated with the estimate: 85%; the middle value does not contradict the limit.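

Compound 4 gives > 150000 nM, which is a limit and not a number. Its steps from compound 1, compound 2 and compound 3 cannot be read, and all four compounds sit together: the limit of > 150000 nM in this assay, at which 4 of the 4 values shown sit. The compounds shown leave open how far the groups on the aromatic nitrogen differ in this read-out, if they differ at all.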